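The source may report more compounds than this note shows. Statements on the series, on what has been measured and on what is new or still open speak of the compounds shown alone.

Measured so far:
compound 1 `CC#C[C@@H](Cc1nnn[nH]1)c1ccc(OCc2cc(Cl)c3scc(-c4ccccc4C)c3c2)cc1` gives 108 nM
compound 2 `CC#C[C@@H](Cc1nnn[nH]1)c1ccc(OCc2ccc3sc(Cl)c(-c4ccccc4C)c3c2)cc1` gives 20 nM
compound 3 `CC#C[C@@H](Cc1nnn[nH]1)c1ccc(OCc2ccc3sc(C)c(-c4ccccc4C)c3c2)cc1` gives 10 nM

All three were tested in a functional assay on cells for agonist activity at Free fatty acid receptor 1 (Rattus norvegicus), read by FLIPR and calcium flux; on this read-out lower numbers stand for an effect already at smaller amounts and higher numbers for an effect only at larger amounts of compound. Compound 1 carries the highest number of the three; compound 2 and compound 3 both lie well below it. The cores of compound 1 and compound 2 hold the same atoms joined differently, and the difference between the two cores is not broken down here.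

From compound 2 to compound 3 one group is exchanged for another: methyl in place of chloro on an aromatic carbon. This step is a 2.0-fold lower number from compound 2 to compound 3 (0.30 log units; within the scatter).

Compound 4 `CC#C[C@@H](Cc1nnn[nH]1)c1ccc(OCc2cc(C)c3scc(-c4ccccc4C)c3c2)cc1` has not yet been measured. It arises from compound 1 by the same kind of change: methyl in place of chloro on an aromatic carbon. Here, however, the change sits on a six-membered ring of carbon only, ortho and meta to a fused ring and meta to a large group, whereas from compound 2 to compound 3 it sits on the five-membered ring next to the ring sulfur. In this assay the step from compound 1 to compound 4 is therefore expected to be about a 2.0-fold lower number from compound 1 to compound 4 (0.29 log units; within the scatter), resting on the step seen from compound 2 to compound 3, which was a 2.0-fold lower number from compound 2 to compound 3 (0.30 log units; within the scatter). Compound 4 is estimated at 55 nM, expected to lie between 25 nM and 150 nM.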

Compound 4, half-maximal effective concentration: 213 nM
Compound 4: the middle estimate sits 3.9-fold (0.59 log units) below what was measured; the measured number lies above the stated range.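

Exchanging chloro for methyl on an aromatic carbon gives a 2.0-fold higher number from compound 1 to compound 4 (0.29 log units; within the scatter), a step that taken alone is no larger than repeated measurements can produce. Set beside the same exchange on the other core, however, the two steps do not agree in this assay: the same change on two cores in this assay, a 2.0-fold lower number (0.30 log units; within the scatter) from compound 2 to compound 3 and a 2.0-fold higher number (0.29 log units; within the scatter) from compound 1 to compound 4, 3.9-fold (0.60 log units) apart, beyond the scatter of two such steps This shows that, in this series, a step read on one core cannot simply be carried over to another; it does not show what sets the two apart, as only two pairs are available, and the exchange sits at a different place in each, so the effect of the core cannot be separated from the effect of the place.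

Going by these compounds, it remains open how other groups on the same six-membered ring, such as fluoro, methoxy or a nitrile, would compare with chloro and methyl. On these data alone, it is also open whether the same exchange would match either step on a further core.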